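Trifluoromethyl in place of ethyl on compound 1

A few compounds are considered here, and "the series" means these few. Any claim that something is new, unique, unknown or untested is made for them only; others in the source may bear on it.

compound 1 `CCc1ccc(NC(=O)Nc2cc(C)nc3ccccc23)cc1`: 17000 nM
compound 2 `COc1ccc(NC(=O)Nc2cc(C)nc3ccccc23)cc1Cl`: > 25000 nM (a limit of the assay)
compound 3 `Cc1cc(NC(=O)Nc2cc(F)cc(F)c2)c2ccccc2n1`: > 25000 nM (a limit of the assay)

Going by the values given here, in an ADME assay on HepG2 cells (Homo sapiens) for cytotoxicity, with a stated time of 72 h (on this read-out lower numbers stand for an effect already at smaller amounts and higher numbers for an effect only at larger amounts of compound), compound 1 gives 17000 nM, the only actual number among the three measured compounds. Compound 2 and compound 3 reach only (the limit of > 25000 nM in this assay, at which 2 of the 3 values shown sit). Compound 4 `Cc1cc(NC(=O)Nc2ccc(C(F)(F)F)cc2)c2ccccc2n1` departs from compound 1 at one place, with trifluoromethyl in place of ethyl on an aromatic carbon. Among the compounds with values here, no measured pair differs at only one place, so the expectation has little to rest on. The estimated step of a 1.1-fold lower number from compound 1 to compound 4 (0.03 log units; within the scatter) is expected to stay within the usual scatter, with no firm direction. For compound 4 the expected value is 16000 nM, within an estimated range of 7000 nM to 25000 nM.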

Compound 4, half-maximal effective concentration: 23000 nM
Beside the measured number, compound 4's estimate is 1.4-fold (0.16 log units) below it; the range from low to high includes it.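

Going by these compounds alone, this is the first step that can be read at a single place. In this assay, trifluoromethyl in place of ethyl on an aromatic carbon, para to a large group, gives a 1.4-fold higher number from compound 1 to compound 4 (0.13 log units; within the scatter), so at this position the exchange does not carry the read-out beyond the scatter. Little room remains for reading any upward change here: the limit of > 25000 nM in this assay, at which 2 of the 4 values shown sit.

The compounds shown leave open whether an amine, a carboxylic acid or a longer chain at this position would give a step beyond the scatter.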